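Benzylamino series: swapping an aromatic side chain for diethylamino

The source may report more compounds than this note shows. Statements on the series, on what has been measured and on what is new or still open speak of the compounds shown alone.

Measured in an ADME assay on J774.A1 cells (Mus musculus) for cytotoxicity, read by MTT assay, with a stated time of 48 h; on this read-out lower numbers stand for higher toxicity in this test and higher numbers for lower toxicity in this test:
- compound 1 `COC(=O)c1c(NCc2ccccc2)noc1-c1ccc([N+](=O)[O-])cc1`: 85400 nM
- compound 2 `COC(=O)c1c(NCc2ccc(OC)c(OC)c2)noc1-c1ccc([N+](=O)[O-])cc1`: "not determined" (no result reported)
- compound 3 `COC(=O)c1c(NCc2ccc(OC)cc2OC)noc1-c1ccc([N+](=O)[O-])cc1`: "not determined" (no result reported)

Only compound 1 carries a number in this series, so it is the sole quantitative anchor. Compound 3 stands without a position on the scale: compound 3 gives "not determined" (no result reported), and compound 2 shares that status with "not determined" (no result reported). Among the compounds with values here, no comparison between measured compounds is therefore available, and the series offers no measured step to serve as a guide.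

The next compound is compound 4 `CCN(CC)CCNc1noc(-c2ccc([N+](=O)[O-])cc2)c1C(=O)OC`, not yet measured. The structural change is (diethylamino)methyl in place of 2,4-dimethoxyphenyl on a saturated chain carbon bound to a nitrogen on an aromatic ring. It puts (diethylamino)methyl in place of 2,4-dimethoxyphenyl on a saturated chain carbon bound to a nitrogen on an aromatic ring, so the aromatic ring of the side chain is lost.

With no number for compound 3, any expectation has to lean on compound 1 at 85400 nM. In this assay a step somewhat beyond the usual scatter is expected, toward lower numbers, and this expectation is weakly founded, as it rests on a single value and on the size of the structural change.

For compound 4 the half-maximal cytotoxic concentration is estimated at 40000 nM, with an expected range of 12000 nM to 120000 nM.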

Compound 4, half-maximal cytotoxic concentration: 69300 nM
For compound 4 the middle estimate is 1.7-fold (0.24 log units) below the measured one; low and high end bracket the measured number.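

Within the data shown here, with (diethylamino)methyl in place of phenyl on a saturated chain carbon bound to a nitrogen on an aromatic ring, this assay gives a 1.2-fold lower number from compound 1 to compound 4 (0.09 log units; within the scatter) and so provides the first readable step, showing that for this pair the aromatic ring of the side chain can be exchanged for an open-chain amine without the read-out moving beyond the usual scatter. The steps from compound 2 and compound 3 to compound 4 cannot be read. No supporting data offer an explanation for this result.

A single pair leaves open how the dimethoxyphenyl side chains of compound 2 and compound 3 compare with either phenyl or (diethylamino)methyl at this position. Also open, on these data alone, is how a morpholine or pyrrolidine in place of the diethylamino group, a longer chain between the two nitrogens, or a carboxylic acid in place of the methyl ester would read in this assay on the shared core.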